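The source may report more compounds than this note shows. Statements on the series, on what has been measured and on what is new or still open speak of the compounds shown alone.

Three compounds built on one shared core were tested in a functional assay on NCI-H460 cells (Homo sapiens) for cytotoxicity, read by MTT assay; on this read-out lower numbers stand for stronger inhibition and higher numbers for weaker inhibition. Compound 1 `COc1ccc(/C=C/C(=O)c2sc(Nc3ccc(Cl)cc3)nc2C)cc1` carries a 4-methoxyphenyl on a double-bonded chain carbon; in this assay compound 1 gives only a limit, > 25000 nM. Compound 2 `COc1cccc(/C=C/C(=O)c2sc(Nc3ccc(Cl)cc3)nc2C)c1` carries a 3-methoxyphenyl at that place instead; in this assay compound 2 likewise gives only a limit, > 25000 nM. Compound 3 `Cc1nc(Nc2ccc(Cl)cc2)sc1C(=O)/C=C/c1ccc(Cl)cc1` carries a 4-chlorophenyl there; in this assay compound 3 also gives only a limit, > 25000 nM. Compound 2 thus stands exactly where the other two stand, at the limit (the limit of > 25000 nM in this assay, at which 3 of the 3 values shown sit). The steps a step that the two limits leave unreadable from compound 1 to compound 2, a step that the two limits leave unreadable from compound 1 to compound 3 and a step that the two limits leave unreadable from compound 2 to compound 3 cannot be read in size for the same reason. Within the data shown here, compound 4 `COc1cccc(/C=C/C(=O)c2sc(Nc3ccc(C)cc3)nc2C)c1` differs from compound 2 by methyl in place of chloro on an aromatic carbon, a change on the (4-chlorophenyl)amino part that none of the measured steps touches. Among the measured compounds shown here, no measured step bears directly on this change; since every measured value sits at the limit (the limit of > 25000 nM in this assay, at which 3 of the 3 values shown sit), the step that the limit leaves unreadable from compound 2 to compound 4 is expected to remain unreadable in the same way. Compound 4 is therefore estimated at 35000 nM, within a range from 10000 nM to 120000 nM.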

Compound 4, half-maximal inhibitory concentration: > 25000 nM
Compound 4 gave a limit, no number; the forecaster's own chance of this, stated with the estimate: 80%; the middle value lies beyond the limit too.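

No new step can be read: swapping chloro for methyl takes compound 2 to compound 4, and both give only a limit, so the size of this change stays unknown: the limit of > 25000 nM in this assay, at which 4 of the 4 values shown sit.

The compounds shown leave open whether any change on the shared core yields an actual number in this assay.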